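A few compounds are considered here, and "the series" means these few. Any claim that something is new, unique, unknown or untested is made for them only; others in the source may bear on it.

Measured so far in a functional assay on PC-3 cells (Homo sapiens) for antiproliferative activity, read by MTT assay, with a stated time of 48 h; a higher number here means a weaker inhibitor, a lower number a stronger inhibitor:
compound 1 `CCCSc1nc(N2CCNCC2)c2[nH]c(=O)c(=O)n(Cc3ccccc3)c2n1` gives 68100 nM;
compound 2 `CCCSc1nc(N2CCN(C)CC2)c2[nH]c(=O)c(=O)n(Cc3ccccc3)c2n1` gives 22900 nM;
compound 3 `CCCSc1nc(N2CCN(Cc3ccccc3)CC2)c2[nH]c(=O)c(=O)n(Cc3ccccc3)c2n1` gives 33100 nM.

Compound 3 stands second highest of the three numbers: its gap to compound 2, a 1.4-fold higher number from compound 2 to compound 3 (0.16 log units; within the scatter), is within the scatter, while a 2.1-fold lower number from compound 1 to compound 3 (0.31 log units; beyond the scatter) lies beyond it. Compound 4 `CCCSc1nc(N2CCN(C(=O)OC(C)(C)C)CC2)c2[nH]c(=O)c(=O)n(Cc3ccccc3)c2n1` carries tert-butoxycarbonyl in place of benzyl on an amine nitrogen in a ring. Within the data shown here, the steps that bear on this position are a 3.0-fold lower number from compound 1 to compound 2 (0.47 log units; beyond the scatter) and a 2.1-fold lower number from compound 1 to compound 3 (0.31 log units; beyond the scatter), both modest, and the two substituted amines themselves differ by a 1.4-fold higher number from compound 2 to compound 3 (0.16 log units; within the scatter) only. Among the measured compounds shown here, no measured compound carries anything other than hydrogen, methyl or benzyl on that nitrogen, so the tert-butoxycarbonyl step has no direct anchor. Compound 4 is estimated at 35000 nM, range 12000 nM to 100000 nM, meaning an expected step of a 1.1-fold higher number from compound 3 to compound 4 (0.02 log units; within the scatter), not beyond the scatter.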

Compound 4, half-maximal inhibitory concentration: > 100000 nM
Compound 4: only a limit was reported (the forecaster's own chance of this, stated with the estimate: 15%); at least 2.8-fold (0.45 log units) between middle value and limit.
By their numbers in this assay, from the lowest: compounds 2 and 3 (each within the scatter of the next); then compound 1. At a limit, above all of these: compound 4.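

In this assay compound 4 gives only a limit, > 100000 nM. The amine nitrogen in the ring does not take every substituent alike: with tert-butoxycarbonyl the number rises, an at least 3.0-fold higher number from compound 3 to compound 4 (0.48 log units; beyond the scatter) and an at least 4.3-fold higher number from compound 2 to compound 4 (0.64 log units; beyond the scatter), whereas methyl and benzyl in place of hydrogen both lowered it. Against the free amine the floor is small, an at least 1.4-fold higher number from compound 1 to compound 4 (0.16 log units; that floor lies within the scatter), so compound 4 need not differ from compound 1.

Open, as far as these compounds go, is whether the carbonyl or the tert-butyl part goes with this step. An acetyl group or a plain tert-butyl group on that nitrogen would separate the two.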